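A few compounds are considered here, and "the series" means these few. Any claim that something is new, unique, unknown or untested is made for them only; others in the source may bear on it.

Measured compounds:
compound 1, `O=C(NC(=S)NNc1ncnc2ccccc12)c1ccccc1F`: 4610 nM
compound 2, `COc1cc2ncnc(NNC(=S)NC(=O)c3ccccc3Cl)c2cc1OC`: 9670 nM
compound 3, `O=C(NC(=S)NNc1ncnc2ccccc12)c1ccc(F)cc1`: 2840 nM

In a functional assay on CNE-2 cells (Homo sapiens) for cytotoxicity, read by MTT assay, with a stated time of 72 h (a higher number here means a weaker inhibitor, a lower number a stronger inhibitor), compound 3 gives the lowest of the three numbers. Compound 1 lies closest to it, and the step of a 1.6-fold lower number from compound 1 to compound 3 (0.21 log units; within the scatter) is within the scatter, so these two cannot be ranked. Compound 2 stands furthest away, and its number in this assay is beyond the scatter from that of compound 3, but the two differ in more than one place, so no single change explains the gap.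

Compound 4, `O=C(NC(=S)NNc1ncnc2ccccc12)c1ccc(Cl)cc1`, differs from compound 3 in one spot: chloro in place of fluoro on an aromatic carbon. No measured step exchanges one halogen for another on this ring; the only step shown moves a fluoro between positions, and compound 2 carries its chloro on a different ring position together with other changes, so it is not a clean guide. With nothing pointing either way, the step of a 1.1-fold lower number from compound 3 to compound 4 (0.04 log units; within the scatter) is expected to stay within the scatter. Compound 4 is therefore estimated at 2600 nM, within a range of 1000 nM to 7000 nM.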

Compound 4, half-maximal inhibitory concentration: 1530 nM
Compound 4: the middle estimate sits 1.7-fold (0.23 log units) above what was measured; the measured number falls inside the stated range.
By their numbers in this assay, from the lowest: compounds 4, 3 and 1 (each within the scatter of the next, the first and the last beyond it); then compound 2.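

Fluoro and chloro can now be compared directly at this spot on the ring, in this assay, and the two cannot be ranked (a 1.9-fold lower number from compound 3 to compound 4 (0.27 log units; within the scatter)). Going by these compounds alone, a wider gap does appear on the ring, and it is the only step on this ring that passes the scatter (a 3.0-fold lower number from compound 1 to compound 4 (0.48 log units; beyond the scatter)). That step changes both the halogen and its place, however, so neither change can be credited alone. Nothing measured here bears on why the numbers differ.

Still open, going by these compounds, is whether a group of another kind at this spot, such as an amine or a carboxylic acid, would move the number beyond the scatter from compound 3. Also open, on these data alone, is whether fluoro and chloro would stay this close on a core carrying other groups.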